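Iodo series: adding the sulfonyl group on the ring nitrogen

The compounds below may be only part of what the source reports. "The series", "measured", "known", "first", "only" and "open" are said of these compounds alone.

Going by the values given here, compound 3 `COc1ccc(-c2[nH]c3cc(OC)cc(OC)c3c(=O)c2I)cc1` gives 49400 nM in a functional assay on KOPN-8 cells (Homo sapiens) for antiproliferative activity, with a stated time of 72 h (on this read-out lower numbers stand for an effect already at smaller amounts and higher numbers for an effect only at larger amounts of compound), the highest of the three numbers measured so far; compound 1 `COc1ccc(-c2c(Cl)c(=O)c3c(OC)cc(OC)cc3n2S(=O)(=O)c2ccc(OC)cc2)cc1` gives 19100 nM and compound 2 `COc1ccc(-c2c(Br)c(=O)c3c(OC)cc(OC)cc3n2S(=O)(=O)c2ccc(OC)cc2)cc1` gives 2580 nM. Compound 4 `COc1ccc(-c2c(I)c(=O)c3c(OC)cc(OC)cc3n2S(=O)(=O)c2ccc(OC)cc2)cc1` differs from compound 3 by (4-methoxyphenyl)sulfonyl in place of hydrogen on an aromatic nitrogen. Among the compounds with values here, no measured pair shows this change directly. Within the data shown here, the only recorded step, a 7.4-fold lower number from compound 1 to compound 2 (0.87 log units; beyond the scatter), concerns bromo in place of chloro and not the nitrogen substituent, so it bears only loosely on the question; compounds 1 and 2 both carry the sulfonyl group and both give lower numbers than compound 3. For compound 4 a lower number than that of compound 3 is therefore expected, roughly a 33-fold lower number from compound 3 to compound 4 (1.52 log units; beyond the scatter). The estimate for compound 4 is 1500 nM, with a range from 300 nM to 8000 nM.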

Compound 4, half-maximal effective concentration: 8580 nM
Compound 4: the middle estimate sits 5.7-fold (0.76 log units) below what was measured; the measured number lies above the stated range.
By their numbers in this assay, from the lowest: compound 2; then compound 4; then compound 1; then compound 3.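

In this assay, going by these compounds alone, the (4-methoxyphenyl)sulfonyl group in place of hydrogen on the aromatic nitrogen gives a 5.8-fold lower number from compound 3 to compound 4 (0.76 log units; beyond the scatter) and so has a direct reading for the first time. With that group kept, iodo gives a 3.3-fold higher number from compound 2 to compound 4 (0.52 log units; beyond the scatter) and a 2.2-fold lower number from compound 1 to compound 4 (0.35 log units; beyond the scatter) so the three halogens do not run in order of chloro, bromo, iodo, and bromo gives the lowest number. Nothing measured here accounts for these steps.

On these data alone, whether the sulfonyl step keeps its size with bromo or chloro stays open. So does the outcome with an acetyl group or a longer alkyl chain on that aromatic nitrogen.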